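The compounds below may be only part of what the source reports. "The series", "measured", "known", "first", "only" and "open" are said of these compounds alone.

Measured so far, both values being limits of the assay and not numbers:

Compound 1 `O=C(CC1S/C(=N\N=C\c2c(-c3ccccc3)[nH]c3ccccc23)NC1=O)c1ccccc1` gives > 50000 nM
Compound 2 `CCC1S/C(=N\N=C\c2c(-c3ccccc3)[nH]c3ccccc23)NC1=O` gives > 50000 nM

In an ADME assay on BJ cells (Homo sapiens) for cytotoxicity, read by fluorescence, with a stated time of 24 h (a higher number here means a weaker inhibitor, a lower number a stronger inhibitor), compound 2 gives > 50000 nM, which is a limit and not a number. The next compound, compound 3 `CCC1S/C(=N\N=C\c2c(-c3ccc([N+](=O)[O-])cc3)[nH]c3ccccc23)NC1=O`, keeps everything in compound 2 except one spot on the phenyl ring: nitro in place of hydrogen on an aromatic carbon. In words, this is nitro in place of hydrogen on an aromatic carbon, para to a large group, turning phenyl into 4-nitrophenyl.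

Within the data shown here, only one measured step is available, a step that the two limits leave unreadable from compound 1 to compound 2. It offers no size to carry forward, and it concerns methyl in place of benzoyl on a saturated chain carbon, not the aromatic ring that changes here. What remains is the limit of > 50000 nM in this assay, at which 2 of the 2 values shown sit. Among the measured compounds shown here, on that ground alone, no step beyond the scatter is expected, although no measurement yet tests this change.

For compound 3 the expected value is 50000 nM, with an estimated range from 20000 nM to 100000 nM. This estimate amounts to an expected a number no higher from compound 2 to compound 3 (the limit leaves the size open).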

Compound 3, half-maximal inhibitory concentration: 29800 nM
For compound 3 the middle estimate is 1.7-fold (0.22 log units) above the measured one; the range from low to high includes it.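

In this assay, among these compounds, compound 3 gives 29800 nM, the only reading of the three that is an actual number and not a limit. This shows that the change from phenyl to 4-nitrophenyl can bring the reading inside the range the assay can measure, and the step is an at least 1.6-fold lower number from compound 2 to compound 3 (0.22 log units; that floor lies within the scatter). The true size of that step stays unknown, and only its floor can be stated, since the reading for compound 2 is a limit and not a number, a position it shares with compound 1: the limit of > 50000 nM in this assay, at which 2 of the 3 values shown sit.

On these data alone, it remains open whether this reading is particular to the nitro group or would also appear with another group on the same phenyl ring, such as an amine, a carboxylic acid or a nitrile, or with the nitro group placed elsewhere on that ring. Also open, as far as these compounds go, is whether the nitro group would give a similar number on the core of compound 1, or with a longer chain on the saturated ring carbon.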